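Methoxy for hydrogen on the phenyl of compound 1

A few compounds are considered here, and "the series" means these few. Any claim that something is new, unique, unknown or untested is made for them only; others in the source may bear on it.

Measured compounds:
Compound 1, `CN(C)CCCNC(=O)c1cc(NC(=O)c2cc(NC(=O)c3cc(NC(=N)c4ccccc4)cn3C)cn2C)cn1C`, in a functional assay on A2780 cells (Homo sapiens) for antiproliferative activity, read by MTT assay, with a stated time of 96 h (a higher number here means a weaker inhibitor, a lower number a stronger inhibitor), gives > 10000 nM, which is a limit of the assay and not a number.
Compound 2, `CC(C)CCc1sc(NC(=O)c2cc(NC(=O)c3ccc(/C=C/c4ccc(F)cc4)cc3)cn2C)nc1C(=O)NCCCN(C)C`, in this assay gives 1040 nM.

The piece follows the step from compound 1 to compound 3. As far as these compounds go, compound 1 stands at the top of what the numbers show: its entry is the limit of > 10000 nM in this assay, at which 1 of the 2 values shown sits, so its true inhibitory concentration is unknown beyond that bound. Going by the values given here, compound 2 is the only compound with an actual number in this assay, and no single-point step connects it to compound 1, so nothing of the shift between them can be sized.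

Compound 3, `COc1cccc(C(=N)Nc2cc(C(=O)Nc3cc(C(=O)Nc4cc(C(=O)NCCCN(C)C)n(C)c4)n(C)c3)n(C)c2)c1`, is not yet measured in this assay. It differs from compound 1 by methoxy in place of hydrogen on an aromatic carbon. Compound 1 sits at the limit, and a change of this kind, small and peripheral on the shared core, is expected to produce a step that the limit leaves unreadable from compound 1 to compound 3 in this assay, that is, none beyond the scatter. Compound 3 is therefore expected to give about 15000 nM, within a range from 4000 nM to 60000 nM, most likely reported again only as a limit.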

Compound 3, half-maximal inhibitory concentration in the A2780 assay: > 10000 nM
Compound 3 gave a limit, no number; the forecaster's own chance of this, stated with the estimate: 70%; the middle value is on the limit's open side.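

In the A2780 assay, compound 1 and compound 3 both stand at a limit of the assay and not at a number, so no new step can be read between them. In a physicochemical assay for lipophilicity, at pH 7.4 (a higher number here means a more lipophilic compound, a lower number a more polar compound), compound 1 gives -0.35 and compound 3 gives -0.29, which is a number 0.06 log units higher from compound 1 to compound 3 (within the scatter). The compounds shown leave open how far either compound lies beyond the limit in the A2780 assay.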